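Buffer stability of the cyclohexylcarbonyl analogue, compound 4

The source may report more compounds than this note shows. Statements on the series, on what has been measured and on what is new or still open speak of the compounds shown alone.

The series is followed in a physicochemical assay for metabolic stability, read by LC-MS, in phosphate buffer, with a stated time of 3 h, at pH 7.4, tested at 50 uM; a lower number here means that less of the compound is left, a higher number that more of the compound is left. Compound 1 `C[C@@H](O)[C@H]1C(=O)N2C(C(=O)OCc3oc(=O)oc3C(C)(C)C)=C(S[C@@H]3CN[C@H](C(=O)Nc4cccc(C(=O)OCc5oc(=O)oc5C(C)(C)C)c4)C3)[C@H](C)[C@H]12` reaches a limit of the assay: in this assay compound 1 gives > 95%, a limit and not a number. Compound 2 `CC(C)C(=O)OCOC(=O)C1=C(S[C@@H]2CN[C@H](C(=O)Nc3cccc(C(=O)O)c3)C2)[C@H](C)[C@@H]2[C@@H]([C@@H](C)O)C(=O)N12` likewise returns a limit, giving > 95% in this assay. Compound 3 `CC(C)C(=O)OCOC(=O)C1=C(S[C@@H]2CN[C@H](C(=O)Nc3cccc(C(=O)OCOC(=O)C(C)C)c3)C2)[C@H](C)[C@@H]2[C@@H]([C@@H](C)O)C(=O)N12` also returns a limit, > 95% in this assay. Going by the values given here, the one step between neighbours that differ in a single place, a step that the two limits leave unreadable from compound 2 to compound 3, is unreadable, both ends sitting at the limit. Where compound 2 stands is thus known only as a limit, and the two further values shown are limits as well; the limit of > 95% in this assay, at which 3 of the 3 values shown sit, sums this up.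

Compound 4 `C[C@@H](O)[C@H]1C(=O)N2C(C(=O)OCOC(=O)C3CCCCC3)=C(S[C@@H]3CN[C@H](C(=O)Nc4cccc(C(=O)O)c4)C3)[C@H](C)[C@H]12` differs from compound 2 in one place: cyclohexyl in place of isopropyl on a carbonyl carbon. Among the compounds with values here, no measured step in this assay joins two actual numbers, so no step size can be carried over; the only evidence is the limit of > 95% in this assay, at which 3 of the 3 values shown sit, with every value at the limit. Compound 4 is therefore expected to show a step that the limit leaves unreadable from compound 2 to compound 4 that is none beyond the scatter. The estimate for compound 4 in this assay is 97%, expected to lie between 92% and 100%.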

Compound 4, percent of the compound remaining: > 95%
Compound 4 gave a limit, no number; the forecaster's own chance of this, stated with the estimate: 85%; the middle value lies beyond the limit too.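

In this assay compound 4 gives > 95%, a limit of the assay and not a number. Going by these compounds alone, compound 2 also stands at a limit, so no step from compound 2 to compound 4 can be read. The compounds shown leave open whether cyclohexyl in place of isopropyl on a carbonyl carbon changes the percent remaining at all, with every value at one limit: the limit of > 95% in this assay, at which 4 of the 4 values shown sit.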